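Replacing the 4-hydroxyphenyl group of compound 2

This account rests on a few compounds, and the source may have more. Where it says the series, first, only, none or still open, it means among the compounds named here.

Compound 1 `O=C(Cc1csc2nc(-c3ccc(Br)cc3)cn12)N/N=C/c1ccccc1O` gives 3310 nM
Compound 2 `O=C(Cc1csc2nc(-c3ccc(Br)cc3)cn12)N/N=C/c1ccc(O)cc1` gives 15500 nM

In a functional assay on SN12C cells (Homo sapiens) for inhibition, read by sulforhodamine B assay, with a stated time of 48 h (a lower number here means a stronger inhibitor of growth, a higher number a weaker inhibitor of growth), compound 2 has the higher number of the two and is the weaker inhibitor of growth in this pair. Compound 3 `O=C(Cc1csc2nc(-c3ccc(Br)cc3)cn12)N/N=C/c1ccc(Cl)cc1Cl` has not yet been measured. It carries 2,4-dichlorophenyl in place of 4-hydroxyphenyl on a carbon with a double bond to nitrogen and otherwise matches compound 2. Among the measured compounds shown here, the only measured step bearing on this is a 4.7-fold higher number from compound 1 to compound 2 (0.67 log units; beyond the scatter) at the same place, with 4-hydroxyphenyl in place of 2-hydroxyphenyl. For the measured compounds named here, no measured compound has 2,4-dichlorophenyl, so this single step is a thin guide. Compound 2 sits at the high end, so a modest move to a lower number is expected, namely a 2.4-fold lower number from compound 2 to compound 3 (0.38 log units; beyond the scatter) as estimated. The estimate for compound 3 is 6500 nM as the expected value, with 2000 nM and 20000 nM as the ends of the expected range.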

Compound 3, concentration for 50% growth inhibition: 85100 nM
Estimate against measurement, compound 3: 13-fold (1.12 log units) below; measured number outside the range, above it.
By their numbers in this assay, from the lowest: compound 1; then compound 2; then compound 3.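

In this assay, among the compounds shown here, the earlier compounds showed only that moving the hydroxyl changes the number at this place on a carbon with a double bond to nitrogen. Replacing a hydroxyphenyl with 2,4-dichlorophenyl, which has 0 hydrogen-bond donors and 0 hydrogen-bond acceptors, raises the number further: the change gives a 5.5-fold higher number from compound 2 to compound 3 (0.74 log units; beyond the scatter) and, on the more active side of the series, a 26-fold higher number from compound 1 to compound 3 (1.41 log units; beyond the scatter), so among these three compounds, compound 3 is the weakest inhibitor of growth. Nothing available gives a reason for this rise.

Because the change removes the hydroxyl and adds two chlorines in one step, these compounds cannot separate the two contributions. Going by these compounds, it remains open how a plain phenyl ring, a ring with a single chlorine, or a ring bearing a methoxy group or an amine would fare here.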